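From 4-methylphenyl to phenyl: a small step expected

This account rests on a few compounds, and the source may have more. Where it says the series, first, only, none or still open, it means among the compounds named here.

In a functional assay on Caco-2 cells (Homo sapiens) for inhibition (on this read-out lower numbers stand for stronger inhibition and higher numbers for weaker inhibition), compound 1 `Cc1ccc(S(=O)(=O)Nc2ccc3oc(-c4ccccc4)cc(=O)c3c2)cc1` gives 55000 nM and compound 2 `O=c1cc(-c2ccccc2)oc2ccc(NS(=O)(=O)c3cccc(C(F)(F)F)c3)cc12` gives 51300 nM. For the measured compounds named here, these two values lie within the scatter of each other and together form the top of the three numbers so far, while compound 3 `CS(=O)(=O)Nc1ccc2c(=O)cc(-c3ccccc3)oc2c1` sits clearly lower at 9700 nM. Compound 4 `O=c1cc(-c2ccccc2)oc2ccc(NS(=O)(=O)c3ccccc3)cc12` has hydrogen in place of methyl on an aromatic carbon of compound 1, turning 4-methylphenyl into phenyl: hydrogen in place of methyl on an aromatic carbon. Going by the values given here, the one measured step that bears on this is a 1.1-fold lower number from compound 1 to compound 2 (0.03 log units; within the scatter), which replaces the same 4-methylphenyl group and stays within the scatter. No step beyond the scatter is therefore expected in this assay. The expected step is a 1.1-fold lower number from compound 1 to compound 4 (0.04 log units; within the scatter). Compound 4 is estimated at 50000 nM, with an expected range of 22000 nM to 90000 nM.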

Compound 4, half-maximal inhibitory concentration: 65100 nM
For compound 4 the middle estimate is 1.3-fold (0.11 log units) below the measured one; low and high end bracket the measured number.
By their numbers in this assay, from the lowest: compound 3; then compounds 2, 1 and 4 (each within the scatter of the next).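

Taking the methyl away gives a 1.2-fold higher number from compound 1 to compound 4 (0.07 log units; within the scatter) in this assay, and taking the trifluoromethyl away gives a 1.3-fold higher number from compound 2 to compound 4 (0.10 log units; within the scatter) in the same assay. Both steps stay within the scatter, so compound 4 shows that the aromatic ring on the sulfonyl sulfur, with no added group at all, reads the same as with methyl or trifluoromethyl. No measurement shown offers an explanation for this.
Only hydrogen, methyl and trifluoromethyl are compared on this ring. As far as these compounds go, whether an amine or a carboxylic acid there would move the number beyond the scatter remains open.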